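The source may hold more compounds than are shown below. What is called first, only, known or untested is meant among the compounds shown, and "the series" means these compounds.

Measured so far in a functional assay (mast cells) for inhibition, with Rattus norvegicus as the target; a higher number here means that more compound is needed for the effect, a lower number that less compound is needed

compound 1 `C[C@H]1CCC(=NNc2ccccc2)c2ncc(C(=O)O)c(=O)n21` gives 600 nM; 8000 nM (2 entries) (two entries)
compound 2 `CC1C/C(=N\Nc2ccccc2)c2ncc(C(=O)O)c(=O)n2C1` gives 13000 nM
compound 3 `CC1CC/C(=N\Nc2ccccc2F)c2ncc(C(=O)O)c(=O)n21` gives 1200 nM

Compound 3 at 1200 nM and compound 2 at 13000 nM, are apart by a gap beyond the scatter, with compound 3 holding the lower number. No single number can be set for compound 1, whose record reads the several entries of compound 1 in this assay, 600 nM; 8000 nM (2 entries) and so leaves its place in the order open.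

The next compound is compound 4 `CC1CC/C(=N\Nc2cccc(Cl)c2)c2ncc(C(=O)O)c(=O)n21`, which carries 3-chlorophenyl in place of 2-fluorophenyl on an amine nitrogen. Within the data shown here, no measured pair differs at this place alone, so the size of this change has no direct precedent. In this assay no step beyond the scatter is expected, and the expected step of a 1.5-fold higher number from compound 3 to compound 4 (0.18 log units; within the scatter) leans only slightly towards a higher number. This expectation starts from compound 3 at 1200 nM and is kept wide given the spread within compound 1. The expected value for compound 4 is 1800 nM within an estimated range of 400 nM to 8000 nM.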

Compound 4, half-maximal effective concentration: 311000 nM
Compound 4: the middle estimate sits 170-fold (2.24 log units) below what was measured, and the stated range ends below it.
By their numbers in this assay, from the lowest: compound 3; then compound 2; then compound 4.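

In this assay the exchange of 2-fluorophenyl for 3-chlorophenyl on the amine nitrogen gives a 260-fold higher number from compound 3 to compound 4 (2.41 log units; beyond the scatter) and so marks this position as highly sensitive to the aryl substituent. The two groups match in heavy-atom count and in hydrogen-bond donor and acceptor counts, so those counts do not account for the step. The step is also far wider than the spread between repeat entries for a single compound, which makes repeat spread an unlikely reading of it: the several entries of compound 1 in this assay, 600 nM; 8000 nM (2 entries)

The change alters both the halogen and its place on the ring, and the compounds shown cannot separate these two contributions. A matched pair carrying 3-fluorophenyl or 2-chlorophenyl would show which of the two carries the step.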